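The source may report more compounds than this note shows. Statements on the series, on what has been measured and on what is new or still open speak of the compounds shown alone.

Three compounds have been measured in an assay on isolated protein for inhibition of Polyunsaturated fatty acid 5-lipoxygenase (Homo sapiens); a lower number here means a stronger inhibitor, a higher number a weaker inhibitor:
compound 1, `NC(=O)N(O)CCC#Cc1ccc(OCCCCN2CCN(C(c3ccc(F)cc3)c3ccc(F)cc3)CC2)cc1`, gives 193 nM;
compound 2, `CC(C)OC(=O)N(O)CCC#Cc1ccc(OCCCCN2CCN(C(c3ccc(F)cc3)c3ccc(F)cc3)CC2)cc1`, gives 335 nM;
compound 3, `CC(C)COC(=O)N(O)CCC#Cc1ccc(OCCCCN2CCN(C(c3ccc(F)cc3)c3ccc(F)cc3)CC2)cc1`, gives 420 nM.

All three share one core and differ only in the group sitting on the carbonyl carbon. Compound 3 has the highest number of the three in this assay: its nearest neighbour is compound 2, whose number is lower within the scatter, and the furthest is compound 1, lower beyond the scatter by a modest margin. The measured steps are these: a 1.7-fold higher number from compound 1 to compound 2 (0.24 log units; within the scatter); a 2.2-fold higher number from compound 1 to compound 3 (0.34 log units; beyond the scatter); a 1.3-fold higher number from compound 2 to compound 3 (0.10 log units; within the scatter).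

Compound 4, `O=C(OCc1ccccc1)N(O)CCC#Cc1ccc(OCCCCN2CCN(C(c3ccc(F)cc3)c3ccc(F)cc3)CC2)cc1`, is the next step from compound 3: phenyl in place of isopropyl on a saturated chain carbon bound to an oxygen next to a carbonyl group. Among the compounds with values here, the one measured step that touches the same part of the molecule is the one from compound 2 to compound 3, and it stayed within the scatter; the two steps from compound 1 show that exchanging the amino group for an isopropoxy or isobutoxy group costs only a little. Nothing measured yet tells how a phenyl ring behaves in that place, so the expectation rests on those steps alone. A step in this assay that is small or within the scatter is therefore expected, leaning slightly toward a higher number: a 1.2-fold higher number from compound 3 to compound 4 (0.09 log units; within the scatter). For compound 4 the estimated value in this assay is 520 nM, with a range from 200 nM to 1400 nM.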

Compound 4, half-maximal inhibitory concentration: 350 nM
Compound 4: middle estimate off by 1.5-fold (0.17 log units), on the high side, within the range that was stated.
By their numbers in this assay, from the lowest: compounds 1, 2, 4 and 3 (each within the scatter of the next, the first and the last beyond it).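

In this assay, within the data shown here, the exchange of isopropyl for phenyl, on a saturated chain carbon bound to an oxygen next to a carbonyl group, brings an aromatic ring into this place for the first time, and it gives a 1.2-fold lower number from compound 3 to compound 4 (0.08 log units; within the scatter) as the whole effect. The other two comparisons read the same way, with a 1.0-fold higher number from compound 2 to compound 4 (0.02 log units; within the scatter) for benzyl in place of isopropyl and a 1.8-fold higher number from compound 1 to compound 4 (0.26 log units; within the scatter) for benzyloxy in place of amino, so a six-membered aromatic ring fits here without a step beyond the scatter, and compound 3 alone remains beyond the scatter of compound 1. No measurement at hand gives a reason for these close numbers.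

As far as these compounds go, whether this flat picture lasts for a benzyl ring carrying a fluorine or a methoxy group, or for a longer chain such as phenethyl, stays open. So does the effect of a methylamino or dimethylamino group on the carbonyl carbon, as amino is the only nitrogen group in that place among these compounds.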